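Adding methoxy to the isopropoxy chain of compound 2

The compounds below may be only part of what the source reports. "The series", "measured", "known", "first", "only" and "open" are said of these compounds alone.

Measured so far in a physicochemical assay for lipophilicity, using the shake flask method; a higher number here means a more lipophilic compound, a lower number a more polar compound:
- compound 1 `Cc1cc(=O)[nH]c(-c2cc(Oc3ccc(S(C)(=O)=O)cc3)cc(OC(C)C)c2)n1` gives 2.43
- compound 2 `CC(C)Oc1cc(Oc2cnc(C(=O)N(C)C)cn2)cc(-c2nccc(=O)[nH]2)c1` gives 1.34
- compound 3 `C[C@@H](CO)Oc1cc(Oc2cnc(C(=O)N(C)C)nc2)cc(-c2nccc(=O)[nH]2)c1` gives -0.02

Compound 2 stands second highest of the three. Compound 1 lies above it and compound 3 lies below it, and both gaps are beyond the scatter.

The next compound is compound 4 `COC[C@H](C)Oc1cc(Oc2cnc(C(=O)N(C)C)cn2)cc(-c2nccc(=O)[nH]2)c1`. Relative to compound 2 the change is methoxy in place of hydrogen on a saturated chain carbon, two bonds along the chain from an oxygen on an aromatic ring, which means methoxy in place of hydrogen on a saturated chain carbon, two bonds along the chain from an oxygen on an aromatic ring. Cut one bond further out, this reads isopropoxy to 1-(methoxymethyl)ethoxy.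

Going by the values given here, no two measured compounds differ in one place only, so this change has no direct precedent. Compound 2 and compound 3 differ in more than one place, so the low reading of compound 3 at -0.02 is only a weak guide. A modest fall in this assay is expected, and it may not clear the scatter. The estimated change is a number 0.24 log units lower from compound 2 to compound 4 (within the scatter). For compound 4 the expected value is 1.1, with an estimated range of 0.75 to 1.45.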

Compound 4, distribution coefficient: 0.81
Estimate against measurement, compound 4: 0.29 log units above; measured number inside the range.
By their numbers in this assay, from the lowest: compound 3; then compound 4; then compound 2; then compound 1.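

In this assay the series now has its first step that changes one place only: methoxy in place of hydrogen on a saturated chain carbon, two bonds along the chain from an oxygen on an aromatic ring, gives a number 0.53 log units lower from compound 2 to compound 4 (beyond the scatter) with the rest of the structure held constant. The earlier compounds shown here differed from each other in more than one place, so none of them could tie a shift in this read-out to the chain alone; the change from isopropoxy to 1-(methoxymethyl)ethoxy now shows that this chain carbon can, by itself, move the number beyond the scatter. Nothing in hand explains the size or direction of this step.

This single step does not show whether the shift follows from methoxy specifically, or whether an amine, a carboxylic acid or a longer chain such as ethoxymethyl at the same chain carbon would move the number further or in the other direction. Also open, from the compounds shown here alone, is whether the same change would give a similar step on the core of compound 1, which carries a different group on its ether oxygen.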